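The compounds below may be only part of what the source reports. "The series", "measured", "known", "first", "only" and "open" are said of these compounds alone.

Measured in an ADME assay on THP-1 cells (Homo sapiens) for cytotoxicity; on this read-out lower numbers stand for higher toxicity in this test and higher numbers for lower toxicity in this test:
Compound 1 `Clc1ccc2nc(-c3ccccn3)c(Nc3ccc4c(c3)OCCO4)n2c1`: > 50000 nM (a limit)
Compound 2 `CN(C)CCNc1c(-c2ccccn2)nc2ccccn12`: > 50000 nM (a limit)

Neither entry is a number. Compound 2 stands at > 50000 nM, which is a limit of the assay. Among the compounds with values here, it shares that position with the only other measured compound: the limit of > 50000 nM in this assay, at which 2 of the 2 values shown sit.

The next compound is compound 3 `c1ccc(-c2nc3ccccn3c2NCC2CC2)nc1`. The change from compound 2 is cyclopropyl in place of (dimethylamino)methyl on a saturated chain carbon bound to a nitrogen on an aromatic ring.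

Within the data shown here, the series offers no measured step between compounds that differ in one place, so the expectation rests only on the limit of compound 2 at > 50000 nM. The estimated step of a number no higher from compound 2 to compound 3 (the limit leaves the size open) is expected to lie within the scatter in this assay, with no direction expected. Compound 3 is estimated at 50000 nM, with an expected range of 20000 nM to 80000 nM.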

Compound 3, half-maximal cytotoxic concentration: 19400 nM
Beside the measured number, compound 3's estimate is 2.6-fold (0.41 log units) above it; measured number outside the range, below it.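

In this assay this position gives the first number rather than a limit: the step reads an at least 2.5-fold lower number from compound 2 to compound 3 (0.41 log units; beyond the scatter), so cyclopropyl in place of (dimethylamino)methyl on a saturated chain carbon bound to a nitrogen on an aromatic ring moves the read-out towards higher toxicity in this test. Compound 2 stands at > 50000 nM, which is a limit and not a number. The full size of the step stays open, and compound 3 is the only compound in the series with a number so far: the limit of > 50000 nM in this assay, at which 2 of the 3 values shown sit.

One step cannot separate the loss of the dimethylamino group from the arrival of the cyclopropyl ring. From the compounds shown here alone, whether a plain propyl chain or a primary amine at the end of the chain would read with compound 2 or with compound 3 remains open.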